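Extending a thioether chain by one carbon

This account rests on a few compounds, and the source may have more. Where it says the series, first, only, none or still open, it means among the compounds named here.

Within the data shown here, compound 2 `CCCCCCCCCCSC[C@H](NC(C)=O)C(=O)CCl` gives the lowest of the two numbers so far in a functional assay on NALM-6 cells (Homo sapiens) (on this read-out higher numbers stand for weaker inhibition and lower numbers for stronger inhibition), with 4700 nM, against compound 1 `CCCCSC[C@H](NC(C)=O)C(=O)CCl`, which in this assay gives 41400 nM. That measured step, an 8.8-fold lower number from compound 1 to compound 2 (0.94 log units; beyond the scatter), is the only one bearing on the next change. Compound 3 `CCCCCCCCCCCSC[C@H](NC(C)=O)C(=O)CCl` differs from compound 2 by methyl in place of hydrogen on a saturated chain carbon, ten or more bonds along the chain from a sulfur. Since adding a whole hexyl yielded only a modest step, a single added methyl is expected to give a step of a 1.4-fold lower number from compound 2 to compound 3 (0.15 log units; within the scatter), probably within the scatter. Compound 3 is therefore estimated at 3300 nM, from 1500 nM to 8000 nM in this assay.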

Compound 3, half-maximal inhibitory concentration: 1700 nM
For compound 3 the middle estimate is 1.9-fold (0.29 log units) above the measured one; measured number inside the range.
By their numbers in this assay, from the lowest: compound 3; then compound 2; then compound 1.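

In this assay methyl in place of hydrogen on a saturated chain carbon gives a 2.8-fold lower number from compound 2 to compound 3 (0.44 log units; beyond the scatter) and so shows that a single added carbon still moves the number. Heptyl in place of hydrogen, four bonds along the chain from a sulfur, gives a 24-fold lower number from compound 1 to compound 3 (1.39 log units; beyond the scatter) and takes the step from modest to large. Nothing available gives a reason for this fall.

Going by these compounds, whether a longer chain lowers the number further remains open, as does the effect of an amine or a carboxylic acid at the chain end.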